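A Bromo for Methyl on the Sulfonyl Aryl Ring

The source may hold more compounds than are shown below. What is called first, only, known or untested is meant among the compounds shown, and "the series" means these compounds.

Measured in a functional assay on QGY-7703 cells (Homo sapiens) for cytotoxicity, read by MTT assay, with a stated time of 24 h; on this read-out lower numbers stand for stronger inhibition and higher numbers for weaker inhibition:
- compound 1 `CN1C/C(=C\c2ccncc2)C(=O)/C(=C/c2ccccc2C(F)(F)F)C1`: 4500 nM
- compound 2 `CN1C/C(=C\c2ccncc2)C(=O)/C(=C/c2ccc(C#N)cc2)C1`: 7400 nM
- compound 3 `Cc1ccc(S(=O)(=O)N2C/C(=C\c3cccnc3)C(=O)/C(=C/c3ccccc3F)C2)cc1`: 9700 nM

Of these three compounds, only compound 3 carries a (4-methylphenyl)sulfonyl group. In this assay, compound 3 gives 9700 nM. That value lies within the scatter of compound 2 at 7400 nM, while it is higher, by more than the scatter, than that of compound 1 at 4500 nM.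

Compound 4 `O=C1/C(=C/c2cccnc2)CN(S(=O)(=O)c2ccc(Br)cc2)C/C1=C\c1ccccc1F` has not yet been measured. It differs from compound 3 in one place: bromo in place of methyl on an aromatic carbon. This is bromo in place of methyl on an aromatic carbon, para to a large group, so that 4-methylphenyl becomes 4-bromophenyl.

Among the measured compounds shown here, no two measured compounds differ in only one place, so the data offer no direct precedent for this change. The expectation therefore rests on compound 3 at 9700 nM as the closest measured relative. A slightly lower number is expected, but no shift beyond the scatter. The estimated step is a 1.3-fold lower number from compound 3 to compound 4 (0.11 log units; within the scatter). For compound 4 the estimated value is 7500 nM, with an expected range of 3000 nM to 17000 nM.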

Compound 4, half-maximal inhibitory concentration: 12800 nM
Compound 4: middle estimate off by 1.7-fold (0.23 log units), on the low side; the range from low to high includes it.
By their numbers in this assay, from the lowest: compounds 1, 2, 3 and 4 (each within the scatter of the next, the first and the last beyond it).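

In this assay, among the compounds shown here, the exchange of 4-methylphenyl for 4-bromophenyl gives a 1.3-fold higher number from compound 3 to compound 4 (0.12 log units; within the scatter) and provides the first pair in this set that differs in only one place. At this position, on an aromatic carbon para to a large group, bromo and methyl cannot be told apart on this read-out, so the (4-methylphenyl)sulfonyl and (4-bromophenyl)sulfonyl compounds stand together within the scatter. No measurement at hand bears on why the two groups read alike.

The compounds shown leave open whether a different group at this same place, such as an amine, a carboxylic acid, a methoxy group or a longer alkyl chain, would move the number beyond the scatter, as bromo does not. They also leave open what the sulfonyl group itself contributes, for compounds 1 and 2 differ from compound 3 and compound 4 in more than one place, and the steps between those compounds cannot be read.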